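A few compounds are considered here, and "the series" means these few. Any claim that something is new, unique, unknown or untested is made for them only; others in the source may bear on it.

Compound 2 `NCCCOc1ccc(CNc2nc3ccc(Oc4ccc(C(F)(F)F)cc4)cc3s2)cc1` is the point of departure. In an assay on cells for inhibition of Voltage-dependent T-type calcium channel subunit alpha-1H (Homo sapiens), read by FLIPR and calcium flux, with stated times of 600 s and 300 s (a higher number here means a weaker inhibitor, a lower number a stronger inhibitor), compound 2 gives 112000 nM. Compound 1 `CN(Cc1ccc(OCCCNC(=N)N)cc1)c1nc2ccc(Oc3ccc(C(F)(F)F)cc3)cc2s1` gives 212000 nM in this assay, a gap from compound 2 that lies within the usual scatter, while compound 3 `CN(Cc1ccc(OCCCN)cc1)c1nc2ccc(Oc3ccc(C(F)(F)F)cc3)cc2s1` gives 248000 nM, a gap from compound 2 that goes beyond it. Compound 4 `NCCCOc1ccc(CNc2nc3ccc(Oc4cccc(C(F)(F)F)c4)cc3s2)cc1` differs from compound 2 by 3-(trifluoromethyl)phenyl in place of 4-(trifluoromethyl)phenyl on an oxygen on an aromatic ring. Neither measured step touches this part of the molecule: a 1.2-fold higher number from compound 1 to compound 3 (0.07 log units; within the scatter) and a 2.2-fold higher number from compound 2 to compound 3 (0.35 log units; beyond the scatter) both concern the amine end of the shared core. Going by the values given here, no measured step therefore speaks to the change, and it is expected to bring no step beyond the scatter, no change at the digits printed from compound 2 to compound 4 (within the scatter). Compound 4 is estimated at 112000 nM, with a range from 50000 nM to 250000 nM.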

Compound 4, half-maximal inhibitory concentration: 171000 nM
Compound 4: middle estimate off by 1.5-fold (0.18 log units), on the low side, within the range that was stated.
By their numbers in this assay, from the lowest: compounds 2, 4, 1 and 3 (each within the scatter of the next, the first and the last beyond it).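

In this assay, 3-(trifluoromethyl)phenyl in place of 4-(trifluoromethyl)phenyl on an oxygen on an aromatic ring gives a 1.5-fold higher number from compound 2 to compound 4 (0.18 log units; within the scatter) and is the only step shown at this place, away from the amine end. This assay therefore does not separate these two groups. No evidence bears on the reason for this result.

Going by these compounds, whether a plain phenyl or a 4-chlorophenyl on that oxygen would give a step beyond the scatter stays open. So does whether the same exchange would read alike on the N-methyl amine of compound 3.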